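Swapping Methyl for Methoxy in Compound 1

A few compounds are considered here, and "the series" means these few. Any claim that something is new, unique, unknown or untested is made for them only; others in the source may bear on it.

Compound 1 `Cc1ccccc1-c1cc2cc(CCC(=O)O)ccc2[nH]1` is the only one of the three measured compounds with a number in a functional assay on CHO cells for agonist activity at Free fatty acid receptor 1 (Homo sapiens), read by a luciferase reporter, with a stated time of 24 h (on this read-out higher numbers stand for an effect only at larger amounts of compound and lower numbers for an effect already at smaller amounts), where compound 1 gives 447 nM. Compound 2 `Cn1c(-c2cccc(Cl)c2)cc2cc(CCC(=O)O)ccc21` reaches only a limit in this assay, namely > 10000 nM. Compound 3 `Cc1ncccc1-c1cc2cc(CCC(=O)O)ccc2[nH]1` likewise shows only a limit, > 25 nM. The step that the limit leaves unreadable from compound 1 to compound 3 therefore cannot be sized, because the result for compound 3 sits at the limit of > 25 nM in this assay, at which 1 of the 3 values shown sits. Compound 4 `COc1ccccc1-c1cc2cc(CCC(=O)O)ccc2[nH]1` differs from compound 1 in one place: methoxy in place of methyl on an aromatic carbon. Among the measured compounds shown here, no measured step exchanges one small group for another on that same aromatic carbon, so no measured step bears directly on this change. Compound 2 differs from compound 1 in more than one place, and its result at the limit of > 10000 nM in this assay, at which 1 of the 3 values shown sits, gives no size either. With no guide from the measured steps, the step of a 1.0-fold higher number from compound 1 to compound 4 (0.00 log units; within the scatter) is expected, lying within the usual scatter. Compound 4 is thus estimated at 450 nM in this assay, with a range from 150 nM to 1500 nM.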

Compound 4, half-maximal effective concentration: > 25 nM
Compound 4: a limit, no number; the forecaster's own chance of this, stated with the estimate: 5%; the middle value is on the limit's open side.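

In this assay compound 4 gives only a limit, > 25 nM, so the step from compound 1 to compound 4 cannot be read and has no size. The compounds shown leave open whether methoxy or methyl at this place gives the lower number.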